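The compounds below may be only part of what the source reports. "The series", "measured", "known", "first", "only" and "open" are said of these compounds alone.

Measured so far, in an ADME assay on microsomes from liver (Rattus norvegicus) for metabolic stability, read by LC-MS, using NADPH, at 37 degrees C; a lower number here means that the compound disappears faster, a higher number that the compound lasts longer:
- compound 1 `CC[C@@H]1C[C@H](CC)CN(CCCNC(=O)C2CCN(Cc3nc(-c4ccccc4C)oc3C)CC2)C1`: compound 1 gives 0.0917 h
- compound 2 `Cc1oc(-c2ccc(Cl)c(Cl)c2)nc1CN1CCC(C(=O)NCCCN2C[C@H](C)C[C@H](C)C2)CC1`: compound 2 reaches only the limit of this assay, > 0.5 h
- compound 3 `Cc1oc(-c2c(Br)cccc2Br)nc1CN1CCC(C(=O)NCCCN2C[C@H](C)C[C@H](C)C2)CC1`: compound 3 gives 0.035 h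

Of the two real numbers, compound 1 gives the higher one, and compound 3 the lower. The limit for compound 2 (the limit of > 0.5 h in this assay, at which 1 of the 3 values shown sits) gives no number to compare. Within the data shown here, the one measured step, an at least 14-fold lower number from compound 2 to compound 3 (1.15 log units; beyond the scatter), changes the aromatic group on the shared core. Compound 4 `CCCN(CCC)CCNC(=O)C1CCN(Cc2nc(-c3ccccc3C)oc2C)CC1` changes something else: dipropylamino in place of (3,5-diethylpiperidin-1-yl)methyl on a saturated chain carbon, two bonds along the chain from an amide-type nitrogen. Among the measured compounds shown here, no measured step touches the amine end of the chain, so there is no ground for expecting a shift beyond the scatter, and compound 4 is expected to show a 1.0-fold lower number from compound 1 to compound 4 (0.01 log units; within the scatter). Compound 4 is therefore estimated at 0.09 h, within 0.04 h to 0.25 h.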

Compound 4, half-life: > 0.5 h
Compound 4 ended at the assay's limit; the forecaster's own chance of this, stated with the estimate: 10%; middle value at least 5.5-fold (0.74 log units) from the limit.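

In this assay, the amine end of the chain moves the result too, not only the aromatic group: dipropylamino in place of (3,5-diethylpiperidin-1-yl)methyl gives an at least 5.4-fold higher number from compound 1 to compound 4 (0.73 log units; beyond the scatter) with the rest of the molecule unchanged. Going by these compounds, compound 4 sits at a limit of the assay rather than at a number, so the full size of this step stays unknown: the limit of > 0.5 h in this assay, at which 2 of the 4 values shown sit. Still open, on these data alone, is how a plain piperidin-1-yl group or a diethylamino group would behave at this position on the same core.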